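Dropping One Hydroxy Group: What to Expect for Compound 3

The source may hold more compounds than are shown below. What is called first, only, known or untested is meant among the compounds shown, and "the series" means these compounds.

Compound 1 `O=C(/C=C/c1ccc2c(c1)B(O)OC2)c1ccco1` gives 7400 nM in a toxicity assay on MCF-10A cells (Homo sapiens) for cytotoxicity, read by MTT assay, with a stated time of 48 h; a lower number here means a stronger inhibitor, a higher number a weaker inhibitor.
Compound 2 `O=C(/C=C/c1ccc2c(c1)B(O)OC2)c1ccc(O)c(O)c1` gives > 100000 nM in this assay, which is a limit and not a number.

The two measured compounds share one core and differ only in the group attached to the carbonyl. Compound 2 sits at the limit of > 100000 nM in this assay, at which 1 of the 2 values shown sits, so all that is known is that it is a weak inhibitor. Compound 3 `O=C(/C=C/c1ccc2c(c1)B(O)OC2)c1cccc(O)c1` comes from compound 2 by hydrogen in place of hydroxy on an aromatic carbon; in words, hydrogen takes the place of one hydroxy on an aromatic carbon. Within the data shown here, no measured pair shows this change, so its size is not known from the data. With compound 2 known only as a limit, the direction of the step in this assay cannot be fixed from the numbers; a modest move toward stronger inhibition is expected, yet a second result at the limit remains plausible. The step expected here is an at least 1.6-fold lower number from compound 2 to compound 3 (0.22 log units; that floor lies within the scatter). Compound 3 is estimated at 60000 nM, with a range from 15000 nM to 150000 nM.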

Compound 3, half-maximal inhibitory concentration: 25300 nM
Estimate against measurement, compound 3: 2.4-fold (0.38 log units) above, and the stated range covers the measured number.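

Taking one hydroxy off the six-membered aromatic ring of compound 2 turns a result at the limit into a real number in this assay, and the step is an at least 3.9-fold lower number from compound 2 to compound 3 (0.59 log units; beyond the scatter) for this change. That step is only a floor, since compound 2 is held at a limit and not at a number: the limit of > 100000 nM in this assay, at which 1 of the 3 values shown sits. The new result also links the series to compound 1: with 3-hydroxyphenyl in place of furan-2-yl on the carbonyl carbon, the move is a 3.4-fold higher number from compound 1 to compound 3 (0.53 log units; beyond the scatter), so one remaining hydroxy still leaves a weaker inhibitor than the furan-2-yl compound.

On these data alone, whether a plain phenyl group on the carbonyl would bring the number closer to that of compound 1 stays open. Also open, as far as these compounds go, is whether an amine or a methoxy in place of the remaining hydroxy would move the number at all.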